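The compounds below may be only part of what the source reports. "The series", "measured", "known", "first", "only" and "open" are said of these compounds alone.

Compound 1 `COc1ccc(CN(C(=O)CSC(=S)N2CCN(C(=O)OC(C)(C)C)CC2)c2ccc(C)cc2)cc1`: > 20000 nM
Compound 2 `COc1ccc(CN(C(=O)CSC(=S)N2CCN(C(=O)OC(C)(C)C)CC2)c2cc(OC)c(OC)c(OC)c2)cc1OC`: > 20000 nM

Both entries are limits, not numbers. In a functional assay on HCT-116 cells (Homo sapiens) for inhibition, read by CCK-8 assay, with a stated time of 48 h (on this read-out higher numbers stand for weaker inhibition and lower numbers for stronger inhibition), compound 2 gives > 20000 nM, a limit of the assay. It therefore shares the limit of > 20000 nM in this assay, at which 2 of the 2 values shown sit, and has no exact position on the scale. Compound 3 `COc1ccc(CN(C(=O)CSC(=S)N2CCN(C(=O)OC(C)(C)C)CC2)c2cc(OC)c(OC)c(OC)c2)cc1O` changes one group of compound 2, with methoxy turning to hydroxy: hydrogen in place of methyl on an oxygen on an aromatic ring. Among the compounds with values here, no measured step shows what such a change does in this assay, so the size is very uncertain. The expected at least 13-fold lower number from compound 2 to compound 3 (1.12 log units; beyond the scatter) runs toward stronger inhibition. Compound 3 is estimated at 1500 nM, within an expected range of 60 nM to 20000 nM.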

Compound 3, half-maximal inhibitory concentration: 128 nM
The estimate for compound 3 lay 12-fold (1.07 log units) above the measured number, and the stated range covers the measured number.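

In this assay, trading one methoxy for hydroxy, which turns 3,4-dimethoxybenzyl into 3-hydroxy-4-methoxybenzyl, gives an at least 150-fold lower number from compound 2 to compound 3 (2.19 log units; beyond the scatter). This single small change therefore separates a compound with no exact position on the scale from one with a measured potency. Compound 2 remains a limit, so the step gives only a minimum size: the limit of > 20000 nM in this assay, at which 2 of the 3 values shown sit.

The compounds shown leave open whether hydroxy is specifically needed on this oxygen-bearing ring position. An amine, a fluorine or a longer ether in its place would help to answer that.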